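This account rests on a few compounds, and the source may have more. Where it says the series, first, only, none or still open, it means among the compounds named here.

Compound 1 `O=C(Nc1ccc(Oc2ccnc3[nH]ccc23)cc1)c1nn(-c2ccc(Cl)cc2)ccc1=O`: 25100 nM
Compound 2 `O=C(Nc1ccc(Oc2ccnc3[nH]ccc23)cc1)c1nn(-c2ccc(Cl)c(C(F)(F)F)c2)ccc1=O`: 2190 nM
Compound 3 `O=C(Nc1ccc(Oc2ccnc3[nH]ccc23)c(F)c1)c1nn(-c2ccc(Cl)cc2)ccc1=O`: > 60000 nM

All three compounds share one core and were tested in a functional assay on A549 cells (Homo sapiens) for cytotoxicity, read by MTT assay, with a stated time of 72 h; on this read-out lower numbers stand for stronger inhibition and higher numbers for weaker inhibition. In this assay compound 1 gives 25100 nM and compound 2 gives 2190 nM; putting trifluoromethyl in place of hydrogen on an aromatic carbon brings an 11-fold lower number from compound 1 to compound 2 (1.06 log units; beyond the scatter). For compound 3 the assay reports only a limit, not a number: compound 3 sits at the limit of > 60000 nM in this assay, at which 1 of the 3 values shown sits. Putting fluoro in place of hydrogen on an aromatic carbon thus brings an at least 2.3-fold higher number from compound 1 to compound 3 (0.37 log units; beyond the scatter), so compound 3 stands as the weakest of the three measured compounds.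

Compound 4 `O=C(Nc1ccc(Oc2ccnc3[nH]ccc23)c(F)c1)c1nn(-c2ccc(Br)cc2)ccc1=O` keeps the fluoro of compound 3 and differs from it in one place: bromo in place of chloro on an aromatic carbon. Neither measured step touches this position, so the two measured steps, one large and one at least modest, give no direct guide for the exchange of chloro for bromo. The expectation is therefore a step that the limit leaves unreadable from compound 3 to compound 4, a change within the scatter, with compound 4 most likely remaining at the limit of this assay. Compound 4 is estimated at 70000 nM, in the range 30000 nM to 160000 nM.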

Compound 4, half-maximal inhibitory concentration: > 60000 nM
Compound 4: no number, only a limit; the forecaster's own chance of this, stated with the estimate: 70%; the middle value is on the limit's open side.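

In this assay compound 4 gives only a limit (> 60000 nM), not a number. Compound 3 also gives only a limit (> 60000 nM), so no step can be read from compound 3 to compound 4. The compounds shown leave open what bromo in place of chloro does in a compound without the fluoro, such as compound 1.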